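The source may report more compounds than this note shows. Statements on the series, on what has been measured and on what is new or still open speak of the compounds shown alone.

Compound 3 `O=C1COc2ccc(NC(=O)C3CCN(c4cccc(Cl)c4)CC3)cc2N1` gives 190 nM in a functional assay for antagonist activity at transient receptor potential cation channel subfamily V member 1 (Homo sapiens), read by FLIPR and calcium flux; on this read-out higher numbers stand for weaker inhibition and lower numbers for stronger inhibition; that value sits within the scatter of compound 2 `O=C1COc2ccc(NC(=O)C3CCN(c4cccc(Br)c4)CC3)cc2N1`, which gives 330 nM, and well apart from compound 1 `O=C(Nc1ccc2c(c1)NC(=O)C(CCO)O2)C1CCN(c2cc(F)c(F)c(F)c2)CC1`, which gives 5 nM. The change 3,4,5-trifluorophenyl in place of 3-chlorophenyl on an amine nitrogen in a ring leads to compound 4 `O=C1COc2ccc(NC(=O)C3CCN(c4cc(F)c(F)c(F)c4)CC3)cc2N1`. Among the compounds with values here, the only measured step, a 1.7-fold lower number from compound 2 to compound 3 (0.24 log units; within the scatter), concerns a different exchange and bears only indirectly on this one. Compound 1 carries the same 3,4,5-trifluorophenyl group as compound 4 but also an extra substituent on its core, so the values of compounds 1 and 3 do not isolate the aryl change. A lower number is nevertheless expected in this assay, a 6.3-fold lower number from compound 3 to compound 4 (0.80 log units; beyond the scatter). Compound 4 is estimated at 30 nM, with a range from 8 nM to 120 nM.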

Compound 4, half-maximal inhibitory concentration: 59 nM
Estimate against measurement, compound 4: 2.0-fold (0.29 log units) below; the measured number falls inside the stated range.
By their numbers in this assay, from the lowest: compound 1; then compound 4; then compounds 3 and 2 (each within the scatter of the next).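

On the amine nitrogen in the ring, 3,4,5-trifluorophenyl now reads cleanly on the shared core in this assay: a 3.2-fold lower number from compound 3 to compound 4 (0.51 log units; beyond the scatter), and a 5.6-fold lower number from compound 2 to compound 4 (0.75 log units; beyond the scatter), both modest. Within the data shown here, the 2-hydroxyethyl group of compound 1 is also isolated for the first time, with hydrogen in its place on the saturated ring carbon giving a 12-fold higher number from compound 1 to compound 4 (1.07 log units; beyond the scatter), a large step. Nothing available offers a reason for either change.

Going by these compounds, whether the 2-hydroxyethyl step carries over to the 3-chlorophenyl or 3-bromophenyl compounds remains open. So does how a longer chain, an amine or a carboxylic acid would behave on that ring carbon.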